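This account rests on a few compounds, and the source may have more. Where it says the series, first, only, none or still open, it means among the compounds named here.

Measured compounds:
compound 1, `COc1ccccc1-c1ccc([C@H]2S[C@@H](C)C(=O)Nc3c2c(C)nn3-c2ccccc2C)cc1`: 1100 nM
compound 2, `CCOc1cccc(-c2ccc([C@H]3S[C@@H](C)C(=O)Nc4c3c(C)nn4-c3ccccc3C)cc2)c1`: 3500 nM
compound 3, `Cc1ccccc1-n1nc(C)c2c1NC(=O)[C@H](C)S[C@@H]2c1ccc(OCc2ccccc2)cc1`: "not active" (no number reported)

Among the compounds with values here, in an assay on isolated protein for agonist activity at Bile acid receptor (Homo sapiens), read by AlphaScreen, with a stated time of 30 min (on this read-out lower numbers stand for an effect already at smaller amounts and higher numbers for an effect only at larger amounts of compound), compound 1 gives 1100 nM and compound 2 gives 3500 nM; the one step that can be read between them is a 3.2-fold higher number from compound 1 to compound 2 (0.50 log units; beyond the scatter). Within the data shown here, compound 3 stands apart from both: in this assay compound 3 is reported only as "not active" (no number reported), so no number is available for it, and no step to compound 1 or compound 2 can be computed.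

Compound 4, `Cc1ccccc1-n1nc(C)c2c1NC(=O)[C@H](C)S[C@@H]2c1ccc(Oc2ccccc2C(=O)O)cc1`, differs from compound 3 in one place: 2-carboxyphenyl in place of benzyl on an oxygen on an aromatic ring. Among the measured compounds shown here, the only measured step concerns a change on the aryl group at a different part of the shared core, not on the oxygen where the benzyl group sits, so it does not bear directly on this change. What remains is that compound 3, with benzyl on that oxygen, gave no number, and that the carboxyphenyl group brings one hydrogen-bond donor and one hydrogen-bond acceptor where benzyl brought none. Any expectation for compound 4 in this assay therefore rests on weak ground and carries a wide range, with a real chance that the assay again reports no number.

Compound 4 is estimated at 3000 nM in this assay, within a range from 300 nM to 30000 nM.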

Compound 4, half-maximal effective concentration: "not active" (no number reported)
Compound 4 has no reported number here; no gap can be computed for the estimate.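

In this assay compound 3 gives "not active" (no number reported) and compound 4 gives "not active" (no number reported) so no new step can be read between them. Nothing in the data shown explains this outcome. The compounds shown leave open whether any group on that oxygen on an aromatic ring can give a number in this assay at all.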